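Benzothiophene in place of a thiophenyl thioether

This account rests on a few compounds, and the source may have more. Where it says the series, first, only, none or still open, it means among the compounds named here.

Compound 3 `CCC(CC)O[C@@H]1C=C(C(=O)O)C[C@H](NCc2ccc(Sc3cccs3)cc2)[C@H]1NC(C)=O` is one of three compounds examined in an ADME assay on MDCK cells (Canis lupus familiaris) for cytotoxicity, read by MTT assay, with a stated time of 48 h; a lower number here means that less compound is tolerated, a higher number that more compound is tolerated. In this assay compound 3 gives > 250000 nM, which is a limit of the assay rather than a measured number. Compound 1 `CCC(CC)O[C@@H]1C=C(C(=O)O)C[C@H](NCc2ccc(OC)cc2)[C@H]1NC(C)=O` gives > 250000 nM, also a limit. Compound 2 `CCC(CC)Oc1ccc(CN[C@H]2CC(C(=O)O)=C[C@@H](OC(CC)CC)[C@@H]2NC(C)=O)cc1` gives > 250000 nM, again a limit. Because (the limit of > 250000 nM in this assay, at which 3 of the 3 values shown sit), none of the steps between these compounds can be read: a step that the two limits leave unreadable from compound 1 to compound 2, a step that the two limits leave unreadable from compound 1 to compound 3 and a step that the two limits leave unreadable from compound 2 to compound 3. Compound 4 `CCC(CC)O[C@@H]1C=C(C(=O)O)C[C@H](NCc2ccc(-c3cc4ccccc4s3)cc2)[C@H]1NC(C)=O` has not yet been tested; it differs from compound 3 by 1-benzothiophen-2-yl in place of (thiophen-2-yl)sulfanyl on an aromatic carbon. With every measured step unreadable, no change beyond the scatter can be foreseen. Compound 4 is therefore expected to sit near 250000 nM, within 90000 nM to 250000 nM, most probably reported once more as a limit. The step of a number no higher from compound 3 to compound 4 (the limit leaves the size open) is expected to be essentially none.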

Compound 4, half-maximal cytotoxic concentration: > 250000 nM
Compound 4: no number, only a limit; the forecaster's own chance of this, stated with the estimate: 85%; the middle value sits exactly at the limit.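

For the compounds shown here, no step from compound 1, compound 2 or compound 3 to compound 4 can be read, because each value is a limit and not a number: the limit of > 250000 nM in this assay, at which 4 of the 4 values shown sit. The compounds shown leave open what concentration of any of them would prove toxic to these cells, and whether the changes between them matter.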